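This account rests on a few compounds, and the source may have more. Where it says the series, first, only, none or still open, it means among the compounds named here.

Compound 1, `Cc1cc(C)cc(-n2nncc2CN2C(=O)C3(C(C#N)=C(N)Oc4c3c3nc5ccccc5nc3c3ccccc43)c3ccccc32)c1`, in a functional assay on MCF7 cells (Homo sapiens) for antiproliferative activity, read by MTT assay, with a stated time of 48 h; a lower number here means a stronger inhibitor, a higher number a weaker inhibitor: > 50000 nM, a limit of the assay.
Compound 2, `Cc1ccc(-n2nncc2CN2C(=O)C3(C(C#N)=C(N)Oc4c3c3nc5ccccc5nc3c3ccccc43)c3ccccc32)c(C)c1`, in this assay: > 50000 nM, also a limit.
Compound 3, `N#CC1=C(N)Oc2c(N)cc3nc4ccccc4nc3c2C12C(=O)N(Cc1cnnn1-c1cccc(Br)c1)c1ccccc12`, in this assay: > 50000 nM, again a limit.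

All three measured compounds share one core, and every value shown sits at the limit (the limit of > 50000 nM in this assay, at which 3 of the 3 values shown sit), so no number is known for any of them. Compound 3 therefore stands on a limit only. Within the data shown here, the single step between measured compounds that differ in one place, a step that the two limits leave unreadable from compound 1 to compound 2, is one the two limits leave unreadable, so neither its size nor its direction can be read.

The unmeasured compound 4, `Cc1ccc(C)c(-n2nncc2CN2C(=O)C3(C(C#N)=C(N)Oc4c(N)cc5nc6ccccc6nc5c43)c3ccccc32)c1`, differs from compound 3 as follows: 2,5-dimethylphenyl in place of 3-bromophenyl on an aromatic nitrogen. A 3-bromophenyl leaves and a 2,5-dimethylphenyl enters on an aromatic nitrogen of a five-membered aromatic ring with 3 nitrogen. Among the measured compounds shown here, the one step that bears on a change of the group on this aromatic nitrogen is the unreadable one, so the measured compounds give no size or direction for the step in this assay.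

Because every value shown sits at the limit of > 50000 nM in this assay, at which 3 of the 3 values shown sit, compound 4 is expected to sit there too. Compound 4 is estimated at 70000 nM, within 25000 nM to 250000 nM. The step that the limit leaves unreadable from compound 3 to compound 4 is expected to be none beyond the scatter.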

Compound 4, half-maximal inhibitory concentration: > 50000 nM
Compound 4 gave a limit, no number; the forecaster's own chance of this, stated with the estimate: 85%; the middle value is on the limit's open side.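

No step can be read between compound 3 and compound 4, because both stand on a limit and neither has a number: the limit of > 50000 nM in this assay, at which 4 of the 4 values shown sit. The compounds shown leave open whether any group on this aromatic nitrogen, or any other change to the shared core, would give a measurable value in this assay at all.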